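Chloro in place of nitro in compound 3

The source may report more compounds than this note shows. Statements on the series, on what has been measured and on what is new or still open speak of the compounds shown alone.

In a functional assay on K562 cells (Homo sapiens) for cytotoxicity, read by sulforhodamine B assay (on this read-out higher numbers stand for weaker inhibition of growth and lower numbers for stronger inhibition of growth), compound 1 `CC1=CC[C@@H]([C@@](C)(O)CCCC(C)(C)NC(=S)N/N=C\c2cccc([N+](=O)[O-])c2)CC1` gives 20 nM, while compound 2 `CC1=CC[C@@H]([C@@](C)(O)CCCC(C)(C)NC(=S)N/N=C\c2ccc([N+](=O)[O-])cc2)CC1` gives 4220 nM, the higher of the two numbers. Compound 3 `CC1=CC[C@@H]([C@@](C)(O)CCCC(C)(C)NC(=S)N/N=C\c2ccc(Cl)cc2)CC1` has not yet been measured. Its difference from compound 2 is chloro in place of nitro on an aromatic carbon, para to a large group. For the measured compounds named here, only one measured step bears on this change. With 4-nitrophenyl in place of 3-nitrophenyl, the result was a 210-fold higher number from compound 1 to compound 2 (2.32 log units; beyond the scatter), a large step. Going by the values given here, that step moved the nitro group without replacing it, and no chloro compound has a measured value, so the evidence is indirect. Since compound 2 sits at the high end with 4220 nM, a moderate move to a lower number is expected, though with wide uncertainty. The expected change is a 7.0-fold lower number from compound 2 to compound 3 (0.85 log units; beyond the scatter). Compound 3 is estimated at 600 nM, with an expected range from 50 nM to 6000 nM.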

Compound 3, concentration for 50% growth inhibition: 40 nM
The estimate for compound 3 lay 15-fold (1.18 log units) above the measured number, outside the stated range (below it).
By their numbers in this assay, from the lowest: compounds 1 and 3 (each within the scatter of the next); then compound 2.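

In this assay, the weak result of compound 2 proves specific to the nitro group and not to substitution at this place on the ring: a 110-fold lower number from compound 2 to compound 3 (2.02 log units; beyond the scatter) comes from chloro alone replacing nitro, para to a large group. The other new step, a 2.0-fold higher number from compound 1 to compound 3 (0.30 log units; within the scatter), lies within the scatter, so 4-chlorophenyl and 3-nitrophenyl cannot be told apart on this read-out, although 4-nitrophenyl stands far from both. Nothing measured here explains why nitro and chloro part so sharply at this place.

From the compounds shown here alone, whether the high number belongs to nitro alone, or would also come with an amine, a carboxylic acid or a methoxy group at this place, stays open. So does whether fluoro or bromo would behave as chloro does.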